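From 3-bromophenyl to 4-bromophenyl on an amine nitrogen

The source may hold more compounds than are shown below. What is called first, only, known or untested is meant among the compounds shown, and "the series" means these compounds.

Compound 1 `S=c1oc(-c2ccc3c(c2)OCCO3)nn1CNc1ccc(Cl)cc1Cl`: 8710 nM
Compound 2 `S=c1oc(-c2ccc3c(c2)OCCO3)nn1CNc1cccc(Br)c1`: 10800 nM

Both values come from a functional assay, with a stated time of 6 min; on this read-out higher numbers stand for weaker inhibition and lower numbers for stronger inhibition. Going by the values given here, compound 2 cannot be separated from compound 1, the only other compound measured, since the data show a 1.2-fold higher number from compound 1 to compound 2 (0.09 log units; within the scatter). Compound 3 `S=c1oc(-c2ccc3c(c2)OCCO3)nn1CNc1ccc(Br)cc1` keeps the shared core and differs from compound 2 in one place: 4-bromophenyl in place of 3-bromophenyl on an amine nitrogen. Among the compounds with values here, no measured pair isolates this change. Within the data shown here, the one measured step that bears on it is the exchange at the same amine nitrogen of 2,4-dichlorophenyl for 3-bromophenyl, which stayed within the scatter. On that single step, no change beyond the scatter is expected in this assay. The expected step is a 1.1-fold lower number from compound 2 to compound 3 (0.06 log units; within the scatter). For compound 3 the estimated value is 9500 nM, with an expected range from 4000 nM to 22000 nM.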

Compound 3, half-maximal inhibitory concentration: 14700 nM
Compound 3: middle estimate off by 1.5-fold (0.19 log units), on the low side; low and high end bracket the measured number.
By their numbers in this assay, from the lowest: compounds 1, 2 and 3 (each within the scatter of the next).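

In this assay, the exchange of 3-bromophenyl for 4-bromophenyl on the amine nitrogen gives a 1.4-fold higher number from compound 2 to compound 3 (0.13 log units; within the scatter) and so isolates where the bromine sits on the phenyl ring, with the halogen itself unchanged. The exchange of 2,4-dichlorophenyl for 4-bromophenyl gives a 1.7-fold higher number from compound 1 to compound 3 (0.23 log units; within the scatter) and also stays within the scatter, so the three halogen-bearing phenyl groups at this position cannot be told apart on this read-out. Nothing at hand accounts for this result.

The compounds shown leave open whether a phenyl group without halogen, a 4-methoxyphenyl group or a cyclohexyl group on this amine nitrogen would give a number in the same range. They also leave open whether a 2-bromophenyl group would stay within the scatter of these three.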